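A few compounds are considered here, and "the series" means these few. Any claim that something is new, unique, unknown or untested is made for them only; others in the source may bear on it.

Measured so far:
compound 1 `COc1cccc(N2CCN(C(=O)CN3C(=O)CC(C)(c4ccccc4)C3=O)CC2)c1` — "not active" (no number reported)
compound 2 `CC1(c2ccccc2)CC(=O)N(CC(=O)N2CCN(c3ccccc3)CC2)C1=O` — 300 mg/kg

Within the data shown here, in a functional assay on the whole organism (strain CD-1) with Mus musculus as the target, with a stated time of 2 h (on this read-out lower numbers stand for an effect already at smaller amounts and higher numbers for an effect only at larger amounts of compound), compound 2 gives 300 mg/kg, the only number; compound 1 stands beside it as "not active" (no number reported), without a number. Compound 3 `COc1ccccc1N1CCN(C(=O)CN2C(=O)CC(C)(c3ccccc3)C2=O)CC1` is not yet measured. It differs from compound 2 in one place: methoxy in place of hydrogen on an aromatic carbon. Among the measured compounds shown here, no step between measured compounds is available, so the size of the change is open; given that compound 1, which also carries a methoxy, is "not active" (no number reported), a step toward larger amounts is expected. Compound 3 is expected at 600 mg/kg, range 250 mg/kg to 1500 mg/kg. The expected step is a 2.0-fold higher number from compound 2 to compound 3 (0.30 log units; within the scatter).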

Compound 3, minimum effective dose: "not active" (no number reported)
For compound 3 the study gives words and no number; the estimate stays without a comparison.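

In this assay, among these compounds, compound 3 is reported in words only, so no step from compound 2 to compound 3 can be read. On these data alone, whether methoxy in place of hydrogen changes the dose needed stays open, and no measured property bears on this result.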